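A few compounds are considered here, and "the series" means these few. Any claim that something is new, unique, unknown or untested is made for them only; others in the source may bear on it.

Measured in a functional assay on Raji cells (Homo sapiens) for cytotoxicity, with a stated time of 72 h; on this read-out higher numbers stand for an effect only at larger amounts of compound and lower numbers for an effect already at smaller amounts:
Compound 1 `C=C[C@@](C)(/C=C/c1ccc(Nc2cc(F)cc(F)c2)cc1)CCC=C(C)C`: > 26000 nM
Compound 2 `C=C[C@@](C)(/C=C/c1ccc(Nc2cc(F)c(F)c(F)c2)cc1)CCC=C(C)C`: > 26000 nM
Compound 3 `C=C[C@@](C)(/C=C/c1ccc(Nc2c(F)cc(F)cc2F)cc1)CCC=C(C)C`: > 26000 nM

Each of these values is a limit of this assay rather than a number. Compound 1 stands at that limit, and so do the other two: the limit of > 26000 nM in this assay, at which 3 of the 3 values shown sit. With all three sitting at the same limit, the changes among them cannot be sized: a step that the two limits leave unreadable from compound 1 to compound 2, a step that the two limits leave unreadable from compound 1 to compound 3 and a step that the two limits leave unreadable from compound 2 to compound 3 all remain unreadable.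

Compound 4 `C=C[C@@](C)(/C=C/c1ccc(-c2cccc(Br)c2)cc1)CCC=C(C)C` has not yet been measured. It differs from compound 1 in one place: 3-bromophenyl in place of (3,5-difluorophenyl)amino on an aromatic carbon. Among the measured compounds shown here, none of the measured steps makes a change of this kind, and none of them gives a readable size, so they offer no basis for expecting a shift in this assay in either direction, nor for expecting none. Compound 4 is therefore estimated at 30000 nM, within a range from 8000 nM to 100000 nM, with a fair chance that only a limit is reported again. The step from compound 1 implied by this estimate is expected to be a step that the limit leaves unreadable from compound 1 to compound 4.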

Compound 4, half-maximal effective concentration: > 26000 nM
Compound 4: only a limit was reported; the forecaster's own chance of this, stated with the estimate: 65%; the middle value is on the limit's open side.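

Compound 4 gives > 26000 nM in this assay, again a limit and not a number. The step from compound 1 to compound 4 therefore cannot be read. The compounds shown leave open at what concentration, if any, each would act on these cells, and whether their structural differences matter.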